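The source may hold more compounds than are shown below. What is called first, only, known or untested is meant among the compounds shown, and "the series" means these compounds.

Compound 2 `C[C@H](CN1CCC(F)CC1)NC(=O)c1ccc(-c2noc(C(F)(F)F)n2)cc1` is measured in an assay on Jurkat E6.1 cells for inhibition of histone deacetylase 4 (Homo sapiens), read by fluorescence (a higher number here means a weaker inhibitor, a lower number a stronger inhibitor), where it gives 100 nM, the highest of the two numbers shown. Its nearest neighbour is compound 1 `C[C@H](CN1CCCC(C)(C)C1)NC(=O)c1ccc(-c2noc(C(F)(F)F)n2)cc1`, which in this assay gives 10 nM; the step of a 10-fold higher number from compound 1 to compound 2 (1.00 log units; beyond the scatter) is modest yet beyond the scatter. Going by the values given here, compound 3 `CCCN(CCC)C[C@@H](C)NC(=O)c1ccc(-c2nc(C(F)(F)F)no2)cc1` in this assay gives > 50000 nM, which is a limit of the assay and not a number, the single value at the limit of > 50000 nM in this assay, at which 1 of the 3 values shown sits. Compound 4 `C[C@H](CN1CCC(F)(F)CC1)NC(=O)c1ccc(-c2noc(C(F)(F)F)n2)cc1` differs from compound 2 by fluoro in place of hydrogen on a saturated ring carbon, that is 4-fluoropiperidin-1-yl to 4,4-difluoropiperidin-1-yl. Among the compounds with values here, the only measured step, a 10-fold higher number from compound 1 to compound 2 (1.00 log units; beyond the scatter), swaps the whole ring group and bears only loosely on this change; no measured step adds a second fluoro to a ring carbon already carrying one. Compound 4 is therefore expected to show no change at the digits printed from compound 2 to compound 4 (within the scatter), not clearly beyond the scatter, at an estimated 100 nM within 40 nM to 300 nM.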

Compound 4, half-maximal inhibitory concentration: 380 nM
For compound 4 the middle estimate is 3.8-fold (0.58 log units) below the measured one, outside the stated range (above it).
By their numbers in this assay, from the lowest: compound 1; then compound 2; then compound 4. At a limit, above all of these: compound 3.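

In this assay, adding a second fluoro to the ring carbon already carrying one is not a silent change: it gives a 3.8-fold higher number from compound 2 to compound 4 (0.58 log units; beyond the scatter), so this ring carbon is sensitive to a single added fluorine. Set against the 3,3-dimethylpiperidin-1-yl ring, the 4,4-difluoropiperidin-1-yl ring gives a 38-fold higher number from compound 1 to compound 4 (1.58 log units; beyond the scatter), the largest step among these ring groups. Nothing measured here accounts for this change. From the compounds shown here alone, it remains open how an unsubstituted piperidin-1-yl ring would compare with compound 2. A hydroxyl or a methyl on the same ring carbon is also an open case.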